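A few compounds are considered here, and "the series" means these few. Any claim that something is new, unique, unknown or untested is made for them only; others in the source may bear on it.

Compound 1: `COc1ccc(C(=O)c2cc(OC)c(OC)c(OC)c2)cc1NC(=O)/C=C/c1cccc(OC(F)(F)F)c1`, giving 7900 nM in a functional assay on COLO 205 cells (Homo sapiens) for cytotoxicity, read by MTT assay, with a stated time of 72 h; on this read-out lower numbers stand for stronger inhibition and higher numbers for weaker inhibition.
Compound 2: `COc1ccc(/C=C/C(=O)Nc2cc(C(=O)c3cc(OC)c(OC)c(OC)c3)cc(OC)c2OC)cc1OC`, giving 5700 nM in this assay.

Of the two numbers shown, the value of compound 2 is the smaller, but its gap to compound 1 lies within the usual scatter, so the two compounds cannot be told apart on these data. Compound 3, `COc1cc(C(=O)c2cc(OC)c(OC)c(OC)c2)cc(NC(=O)/C=C/c2ccc(C(F)(F)F)cc2)c1OC`, differs from compound 2 by 4-(trifluoromethyl)phenyl in place of 3,4-dimethoxyphenyl on a double-bonded chain carbon bound to a double-bonded chain carbon. For the measured compounds named here, no step between measured compounds is available as a guide, and both measured values sit in the same range. Compound 3 is therefore expected to change by a 1.2-fold higher number from compound 2 to compound 3 (0.09 log units; within the scatter), a step not beyond the scatter. Compound 3 is estimated at 7000 nM, with a range from 2500 nM to 20000 nM.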

Compound 3, half-maximal inhibitory concentration: 2500 nM
Compound 3: middle estimate off by 2.8-fold (0.45 log units), on the high side; low and high end bracket the measured number.
By their numbers in this assay, from the lowest: compound 3; then compounds 2 and 1 (each within the scatter of the next).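

In this assay, for the compounds shown here, 4-(trifluoromethyl)phenyl in place of 3,4-dimethoxyphenyl on a double-bonded chain carbon bound to a double-bonded chain carbon gives a 2.3-fold lower number from compound 2 to compound 3 (0.36 log units; beyond the scatter) and so provides the first step here beyond the scatter. This shows that the number responds to the group at this position, although the size of the step is modest. Nothing shown explains this step. Going by these compounds, whether an amine or a carboxylic acid on this phenyl ring would lower the number further remains open, as does the effect of a longer chain in place of the ethenyl link.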